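The compounds below may be only part of what the source reports. "The series", "measured", "known", "first", "only" and "open" are said of these compounds alone.

Measured so far in a functional assay on ileum for inhibition of histamine H1 receptor (Cavia porcellus); on this read-out lower numbers stand for stronger inhibition and higher numbers for weaker inhibition:

Compound 1, `CCCC(C)n1c(N2CCN(C)CC2)nc2ccccc21`, gives 1400 nM.
Compound 2, `CCOCCn1c(N2CCN(C(c3ccccc3)c3ccccc3)CC2)nc2ccccc21`, is reported only as a limit of the assay: > 3000 nM.
Compound 3, `CCOCCn1c(N2CCN(c3ccccc3)CC2)nc2ccccc21`, is likewise reported only as a limit of the assay: > 10000 nM.

Compound 1 is therefore the only one of the three with an actual number in this assay. The two others sit at limits: one at the limit of > 3000 nM in this assay, at which 1 of the 3 values shown sits, and one at the limit of > 10000 nM in this assay, at which 1 of the 3 values shown sits. Among the compounds with values here, since compound 2 and compound 3 differ from compound 1 in more than one place, no single step between measured compounds can be drawn, and their limits show only that they were not resolved as numbers.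

Compound 4, `CN1CCN(c2nc3ccccc3n2CCOCCO)CC1`, is not yet measured. It differs from compound 1 as follows: 2-(2-hydroxyethoxy)ethyl in place of 1-methylbutyl on an aromatic nitrogen.

Within the data shown here, with no measured step of this kind to lean on, only a rough expectation is possible. The change is expected to weaken inhibition modestly, by a 2.5-fold higher number from compound 1 to compound 4 (0.40 log units; beyond the scatter), somewhat beyond the usual scatter, with a real chance that the assay again reports a limit. Compound 4 is thus estimated at 3500 nM in this assay, within a range from 1200 nM to 12000 nM.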

Compound 4, half-maximal inhibitory concentration: 42 nM
Compound 4: middle estimate off by 83-fold (1.92 log units), on the high side, outside the stated range (below it).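

At this position on the aromatic nitrogen, the side chain has a far larger influence than compound 1 alone could show: in this assay, 2-(2-hydroxyethoxy)ethyl in place of 1-methylbutyl gives a 33-fold lower number from compound 1 to compound 4 (1.52 log units; beyond the scatter) and so a large gain in inhibition, with the 4-methylpiperazin-1-yl group unchanged. The entering chain carries oxygen atoms and a hydrogen-bond donor while the leaving one has neither, but this single swap changes all of these together. Compound 2 and compound 3 differ from compound 1 and compound 4 in more than one place, so no steps to them can be read, and nothing shown explains the size of this gain.

On these data alone, whether the hydroxyl, the ether oxygen or the chain length matters most stays open. A shorter 2-hydroxyethyl chain or a 2-(2-methoxyethoxy)ethyl chain on the same core would help separate these effects.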